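The source may report more compounds than this note shows. Statements on the series, on what has been measured and on what is new or still open speak of the compounds shown alone.

In an assay on isolated protein for inhibition of Dihydrofolate reductase (Homo sapiens), read by spectrophotometry (on this read-out higher numbers stand for weaker inhibition and lower numbers for stronger inhibition), three compounds built on one shared core have been measured. Compound 1 `COc1ccc(N(C)Cc2nc3cc(C(F)(F)F)ccc3nc2-c2ccccc2)cc1` gives 3000 nM. Compound 2 `Cc1ccc(N(C)Cc2nc3cc(C(F)(F)F)ccc3nc2-c2ccccc2)cc1` gives 11000 nM, and the step of a 3.7-fold higher number from compound 1 to compound 2 (0.56 log units; beyond the scatter) comes from a methyl in place of methoxy on an aromatic carbon. Compound 3 `CCN(Cc1nc2cc(C(F)(F)F)ccc2nc1-c1ccccc1)c1ccc(OC)cc1` gives 7000 nM; the step of a 2.3-fold higher number from compound 1 to compound 3 (0.37 log units; beyond the scatter) comes from a methyl in place of hydrogen on a saturated chain carbon bound to a nitrogen on an aromatic ring. Among the three, compound 3 stands second highest, and its gap to compound 2 is within the scatter.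

Compound 4 `CCN(Cc1nc2cc(C(F)(F)F)ccc2nc1-c1ccccc1)c1ccc(OC)c(OC)c1` differs from compound 3 by methoxy in place of hydrogen on an aromatic carbon, a change that turns the 4-methoxyphenyl into 3,4-dimethoxyphenyl. Within the data shown here, neither measured step adds a methoxy group, so no step here bears directly on this change; both measured steps were modest. The expected step is therefore no change at the digits printed from compound 3 to compound 4 (within the scatter), with no change beyond the scatter as the likeliest outcome. The estimate for compound 4 in this assay is 7000 nM, within a range from 2500 nM to 20000 nM.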

Compound 4, inhibition constant: 4000 nM
Compound 4: middle estimate off by 1.8-fold (0.24 log units), on the high side; the range from low to high includes it.
By their numbers in this assay, from the lowest: compounds 1, 4, 3 and 2 (each within the scatter of the next, the first and the last beyond it).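

In this assay, placing a second methoxy on the aromatic carbon ortho to the existing methoxy group, which turns 4-methoxyphenyl into 3,4-dimethoxyphenyl, gives a 1.8-fold lower number from compound 3 to compound 4 (0.24 log units; within the scatter). Among these compounds, this is the first measured change at this ring carbon, since the earlier steps altered the existing methoxy group and the chain on the nitrogen, and here the added group leaves the number within the usual scatter. Nothing shown gives a reason for this result.

Still open, going by these compounds, is whether a different group on this same ring carbon, such as fluorine, an amine or a carboxylic acid, would give a step beyond the scatter. On these data alone, it is also open whether this added methoxy would give a similar step on compound 1, which has a methyl instead of an ethyl on the nitrogen.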